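From 2-chlorophenyl to 4-methoxyphenyl on the shared core

The source may hold more compounds than are shown below. What is called first, only, known or untested is meant among the compounds shown, and "the series" means these compounds.

In a functional assay on the whole organism (strain Kunming) with Mus musculus as the target, in the formalin test, with a stated time of 0.5 h (a lower number here means that less compound is needed, a higher number that more compound is needed for the effect), compound 2 `COc1cc(OC)c(OC)cc1/C=C/COC(=O)/C=C/c1ccccc1Cl` gives 101 mg/kg and compound 1 `COc1ccccc1/C=C/C(=O)OC/C=C/c1cc(OC)c(OC)cc1OC` gives 113 mg/kg, so these two sit within the scatter of each other. Compound 3 `COc1ccc(/C=C/C(=O)OC/C=C/c2cc(OC)c(OC)cc2OC)cc1` differs from compound 2 by one change: 4-methoxyphenyl in place of 2-chlorophenyl on a double-bonded chain carbon bound to a double-bonded chain carbon. Among the compounds with values here, the only measured step that bears on this is a 1.1-fold lower number from compound 1 to compound 2 (0.05 log units; within the scatter), where chloro took the place of methoxy on an aromatic carbon. Within the data shown here, no compound with the 4-methoxyphenyl group has been measured yet, so this guide is limited. Going by that small step, the expected change is a 1.0-fold higher number from compound 2 to compound 3 (0.02 log units; within the scatter). Compound 3 is expected at 105 mg/kg, with an estimated range of 50 mg/kg to 220 mg/kg.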

Compound 3, dose for half-maximal effect: 122 mg/kg
The estimate for compound 3 lay 1.2-fold (0.07 log units) below the measured number; measured number inside the range.
By their numbers in this assay, from the lowest: compounds 2, 1 and 3 (each within the scatter of the next).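

In this assay, 4-methoxyphenyl in place of 2-chlorophenyl gives a 1.2-fold higher number from compound 2 to compound 3 (0.08 log units; within the scatter) and 4-methoxyphenyl in place of 2-methoxyphenyl gives a 1.1-fold higher number from compound 1 to compound 3 (0.03 log units; within the scatter), both on the same double-bonded chain carbon. Thus neither exchanging the group nor comparing 2-methoxyphenyl with 4-methoxyphenyl moves the number beyond the scatter in these compounds. No measured evidence is available to explain this result. Still open, from the compounds shown here alone, is whether a phenyl group carrying an amine or a carboxylic acid would give a number beyond the scatter of these three compounds.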